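Expected Rat Clearance of Compound 3 After One Methyl Added

A few compounds are considered here, and "the series" means these few. Any claim that something is new, unique, unknown or untested is made for them only; others in the source may bear on it.

Compound 1 `CCCC(=O)Nc1cccnc1NCc1ccc(-c2ccccc2C(=O)OC)cc1`: 23 mL/min/kg
Compound 2 `CNC(=O)c1ccccc1-c1ccc(CNc2nccc(C)c2NC(=O)CC(F)(F)F)cc1`: 30 mL/min/kg

In an in vivo ADME assay on the whole organism (Rattus norvegicus, strain Sprague Dawley) for pharmacokinetics (on this read-out lower numbers stand for slow clearance and higher numbers for fast clearance), compound 1 gives 23 mL/min/kg. Compound 2, in this assay, gives 30 mL/min/kg, the higher of the two numbers shown, but its gap to compound 1 lies within the usual scatter of repeated measurements, so the two compounds cannot be told apart on this read-out, and no order between them is claimed.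

Compound 3 `CNC(=O)c1ccccc1-c1ccc([C@@H](C)Nc2nccc(C)c2NC(=O)CC(F)(F)F)cc1` has not yet been measured. It differs from compound 2 in one place: methyl in place of hydrogen on a saturated chain carbon bound to an aromatic carbon and a nitrogen on an aromatic ring. Within the data shown here, no pair of measured compounds shows this same change, so the data give no step from which its size could be read. Among the measured compounds shown here, with only two measured numbers, both close to each other, the expectation rests on compound 2 alone. The step from compound 2 to compound 3 in this assay is expected to be a 1.1-fold lower number from compound 2 to compound 3 (0.05 log units; within the scatter), which is no change beyond the scatter. Compound 3 is therefore estimated at 27 mL/min/kg in this assay, with a range from 13 mL/min/kg to 55 mL/min/kg.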

Compound 3, clearance: 31 mL/min/kg
Compound 3: middle estimate off by 1.1-fold (0.06 log units), on the low side; the range from low to high includes it.
By their numbers in this assay, from the lowest: compounds 1, 2 and 3 (each within the scatter of the next).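

In this assay, methyl in place of hydrogen on a saturated chain carbon bound to an aromatic carbon and a nitrogen on an aromatic ring gives a 1.0-fold higher number from compound 2 to compound 3 (0.01 log units; within the scatter), so compound 2 and compound 3 cannot be told apart on this read-out. Among these compounds, this is the first step that can be read at this position, since compound 1 and compound 2 differ in more than one place, and it shows that this carbon can carry the methyl with no difference beyond the scatter in rat clearance. Nothing shown gives a reason for this result.

A single step at a single position leaves open whether a longer chain such as ethyl, or a group such as an amine or a carboxylic acid, on this same carbon would also stay within the scatter of compound 2. It also leaves open whether the same methyl would give a similar step on the core of compound 1, and whether the opposite arrangement at this carbon would match compound 3.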